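Phenyl to Pyridin-3-yl in a Shared Sulfonamide Core

The source may report more compounds than this note shows. Statements on the series, on what has been measured and on what is new or still open speak of the compounds shown alone.

Three measured compounds share one core: compound 1 `COc1ccc(-c2csc(C(=O)N(C)C)c2)cc1S(=O)(=O)Nc1cccc(NCCNC(=O)c2cccc(C)c2)c1`, compound 2 `COc1ccc(-c2cccc(C(=O)NCCN(C)C)c2)cc1S(=O)(=O)Nc1cccc(NCCNC(=O)c2cccc(C)c2)c1` and compound 3 `COc1ccc(-c2cccc(C(=O)N(C)Cc3ccccc3)c2)cc1S(=O)(=O)Nc1cccc(NCCNC(=O)c2cccc(C)c2)c1`. In a functional assay on CHO-RD-HGA16 cells for agonist activity at Orexin receptor type 2 (Homo sapiens), read by fluorescence and calcium flux, with a stated time of 30 min (a lower number here means a smaller maximal response, a higher number a larger maximal response), compound 1 gives 68%, compound 2 gives 64% and compound 3 gives 61%. Compound 3 has the lowest of the three numbers, but its gaps to both others lie within the scatter, so no order can be read from them. Within the data shown here, the only counted step, a number 3 percentage points lower from compound 2 to compound 3 (within the scatter), alters the group on the carbonyl carbon without moving the response beyond the scatter. Compound 4 `COc1ccc(-c2cccc(C(=O)N(C)Cc3cccnc3)c2)cc1S(=O)(=O)Nc1cccc(NCCNC(=O)c2cccc(C)c2)c1` differs from compound 3 as pyridin-3-yl in place of phenyl on a saturated chain carbon bound to an amide-type nitrogen. Among the measured compounds shown here, no measured step tests this exact swap, and the one change at the same group was small, so no shift beyond the scatter is expected in this assay. Compound 4 is estimated at 60%, within 50% to 70%. This expected result corresponds to a number 1 percentage points lower from compound 3 to compound 4 (within the scatter).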

Compound 4, largest response reached (Emax), in percent of the reference or control that the assay uses: 75%
Compound 4: the middle estimate sits 15 percentage points below what was measured; the whole stated range lies below it.
By their numbers in this assay, from the lowest: compounds 3, 2, 1 and 4 (each within the scatter of the next, the first and the last beyond it).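

In this assay, among these compounds, the ring on the saturated chain carbon bound to an amide-type nitrogen does count: pyridin-3-yl in place of phenyl gives a number 14 percentage points higher from compound 3 to compound 4 (beyond the scatter) and is the first single change here to clear the scatter. Methyl((pyridin-3-yl)methyl)amino in place of (2-(dimethylamino)ethyl)amino on the carbonyl carbon also clears it, with a number 11 percentage points higher from compound 2 to compound 4 (beyond the scatter), which benzyl(methyl)amino at that carbon did not do. Nothing shown gives a cause for either step.

Open, as far as these compounds go, is whether pyridin-4-yl or pyridin-2-yl on the same chain carbon would match compound 4, and whether an amine on the pyridine ring would keep the response.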